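The source may report more compounds than this note shows. Statements on the series, on what has been measured and on what is new or still open speak of the compounds shown alone.

Two compounds of the same core have been followed in a physicochemical assay, at pH 7.4; on this read-out higher numbers stand for a longer-lived compound and lower numbers for a shorter-lived compound. Compound 1, `CO[C@H]1C(=O)N2C(C(=O)C(C)(C)C)=C(C)[C@@H](Sc3nc(=O)c(=O)[nH]n3C)S(=O)(=O)C12`, gives 21 h in this assay, the higher of the two numbers. Compound 2, `CO[C@H]1C(=O)N2C(C(=O)C(C)(C)C)=C(C)[C@@H](OC(=O)c3ccc(CSc4nc(=O)c(=O)[nH]n4C)cc3)S(=O)(=O)C12`, which carries a different group on the saturated ring carbon, gives 7.5 h in this assay, and the gap between these two values lies beyond the usual scatter of the measurement. The next compound, compound 3, `CO[C@H]1C(=O)N2C(C(=O)C(C)(C)C)=C(C)[C@@H](Sc3ccccn3)S(=O)(=O)C12`, keeps the sulfur on the saturated ring carbon but changes what hangs from it: a group of 6 heavy atoms (5 carbon, 1 nitrogen; one six-membered aromatic ring with 1 hetero atom) in place of a group of 9 heavy atoms (4 carbon, 3 nitrogen, 2 oxygen; one six-membered aromatic ring with 3 hetero atoms), on a sulfur. Among the measured compounds shown here, no pair of compounds that differ only in this way has been measured, so there is no directly comparable step to lean on. The single known contrast, compound 1 against compound 2, concerns a larger rebuild rather than a swap of one ring for another. On that footing, the step from compound 1 to compound 3 is expected to stay within the scatter, estimated as a 1.4-fold lower number from compound 1 to compound 3 (0.15 log units; within the scatter). Compound 3 is therefore expected to give about 15 h in this assay, within a range of 5 h to 45 h.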

Compound 3, half-life: 24 h
Beside the measured number, compound 3's estimate is 1.6-fold (0.20 log units) below it, within the range that was stated.
By their numbers in this assay, from the lowest: compound 2; then compounds 1 and 3 (each within the scatter of the next).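

In this assay, exchanging the ring carried by the sulfur gives a 1.1-fold higher number from compound 1 to compound 3 (0.06 log units; within the scatter), a step that lies within the scatter. Among the compounds shown here, this is the first direct reading of a change at this place: with the sulfur on the saturated ring carbon kept, a pyridin-2-yl group takes the place of a group with more heavy atoms, a hydrogen-bond donor and double bonds outside its ring, yet the half-life cannot be told apart between the two compounds. For the compounds shown here, nothing measured so far offers an explanation for this result.

As far as these compounds go, one exchange says little about the position as a whole, so it remains open whether an amine, a carboxylic acid or a longer chain such as n-butyl on that sulfur would also leave the half-life within the scatter of compound 1. Also open, from the compounds shown here alone, is whether a plain phenyl ring, which lacks the ring nitrogen of pyridin-2-yl, would read the same, and whether this result would hold on a different core.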